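A few compounds are considered here, and "the series" means these few. Any claim that something is new, unique, unknown or untested is made for them only; others in the source may bear on it.

Measured compounds in a functional assay (brain) for inhibition, with Rattus norvegicus as the target; a higher number here means a weaker inhibitor, a lower number a stronger inhibitor:

compound 1 `Cc1c(C)c2c(c(C)c1O)CCC(C)(C(=O)[N-][N+](C)(C)C)O2`: compound 1 gives 14000 nM
compound 2 `Cc1c(C)c2c(c(C)c1O)CC[C@](C)(CC[S+](C)C)O2`: compound 2 gives 2000 nM
compound 3 `Cc1c(C)c2c(c(C)c1O)CC[C@@](C)(CC[S+](C)C)O2`: compound 3 gives 2000 nM

Compound 3 stands level with compound 2 in this assay at the digits printed, and the two together give the lowest numbers of the three; compound 1 sits well apart from them at the higher end, beyond the scatter.

Going by the values given here, the only step measured within this pair of numbers is no change at the digits printed from compound 2 to compound 3 (within the scatter). The two compounds have the same atoms and bonds and differ only in the configuration as drawn (the fact that compounds 2 and 3 differ only in the configuration as drawn), and the measured numbers do not separate them.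

Compound 4 `Cc1c(C)c2c(c(C)c1O)CCC(C)(CC[S+](C)C)O2` is next. The change from compound 3 is the two compounds have the same atoms and bonds; at least one stereo element is drawn with a configuration in one of them and without one in the other: 1 of 1 stereo elements differ; a stereocentre at a saturated ring carbon is drawn S in compound 3 and without a configuration in compound 4. Since compound 2 and compound 3 each carry one of the two drawn configurations and give the same number in this assay, material drawn without a configuration at that centre is expected to fall at the same level: the expected step is no change at the digits printed from compound 3 to compound 4 (within the scatter), that is, none beyond the scatter.

Compound 4 is therefore estimated at 2000 nM in this assay, with a range of 1000 nM to 4000 nM.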

Compound 4, half-maximal inhibitory concentration: 2000 nM
Compound 4: the middle estimate sits on the measured number at the digits printed; the range from low to high includes it.
By their numbers in this assay, from the lowest: compounds 2, 3 and 4 (each within the scatter of the next); then compound 1.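

Compound 4 closes the set at this centre, so that the drawn R form, the drawn S form and material drawn without a configuration can all be read in this assay: no change at the digits printed from compound 3 to compound 4 (within the scatter) and no change at the digits printed from compound 2 to compound 4 (within the scatter). Neither step separates the undefined material from a defined form, so the configuration at this saturated ring carbon has no measured bearing on the number in this set, on the following basis: the fact that one of compounds 2 and 4 is drawn with a defined configuration and the other without, at the place where they differ

Going by these compounds alone, compound 4 also gives the first like-for-like reading of the side group, since it and compound 1 are both drawn without a configuration at that carbon, and the group of 5 heavy atoms in place of the group of 7 heavy atoms gives a 7.0-fold lower number from compound 1 to compound 4 (0.85 log units; beyond the scatter).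

That step exchanges the whole group at once, so the compounds shown do not tell which part of it goes with the lower number. On these data alone, how a primary amine, a carboxylic acid or a longer chain ending in the same sulfur group would read at this saturated ring carbon in this assay also stays open.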